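The compounds below may be only part of what the source reports. "The series", "measured", "known", "first", "only" and "open" are said of these compounds alone.

Measured compounds in a functional assay on the whole organism (strain albino) for inhibition, with Rattus norvegicus as the target, read by paw edema, with stated times of 30 min and 1 h, at a dose of 0.28 mmol/kg by the oral route; on this read-out higher numbers stand for more inhibition at the one dose given (going by the name of the read-out) and lower numbers for less inhibition:
compound 1 `CCn1c(SCC(=O)Nc2ccc(/C(C)=N/O)cc2)nnc1-c1ccc(OC)cc1` gives 54%
compound 2 `CCn1c(SCC(=O)Nc2ccc(C(C)=O)cc2)nnc1-c1ccc(OC)c(OC)c1` gives 56%
compound 3 `CCn1c(SCC(=O)Nc2ccc(C(C)=O)cc2)nnc1-c1cc(OC)c(OC)c(OC)c1` gives 46%

Compound 2 gives the highest of the three numbers in this assay, but its nearest neighbour compound 1 sits only a little lower and its furthest neighbour compound 3 sits lower by a number 10 percentage points lower from compound 2 to compound 3 (within the scatter), so none of the three is separated from the others beyond the usual scatter. Among the compounds with values here, the one measured step that bears on the next compound is that from compound 2 to compound 3, a methoxy in place of hydrogen on an aromatic carbon, which gave a number 10 percentage points lower from compound 2 to compound 3 (within the scatter).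

Compound 4 `CCn1c(SCC(=O)Nc2ccc(C(C)=O)cc2)nnc1-c1ccc(OC)cc1` is compound 2 with one methoxy taken away: hydrogen in place of methoxy on an aromatic carbon. Within the data shown here, this is the reverse direction of the single measured step, which itself stayed within the scatter. Compound 1 carries the same 4-methoxyphenyl group on the same core with an oxime instead of the acetyl and gives a number close to compound 2; no step is computed for that pair, so only the two values are shown. With the measured step being small, the expected change from compound 2 to compound 4 is a number 3 percentage points lower from compound 2 to compound 4 (within the scatter), a step not beyond the scatter and of no clear direction. Compound 4 is therefore estimated at 53% in this assay, with a range from 41% to 65%.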

Compound 4, a percentage reported as inhibition, in the whole organism at one dose (the size of the read-out at that dose, not a potency): 51%
Compound 4: the middle estimate sits 2 percentage points above what was measured, within the range that was stated.
By their numbers in this assay, from the lowest: compounds 3, 4, 1 and 2 (each within the scatter of the next).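

In this assay, going from 3,4-dimethoxyphenyl to 4-methoxyphenyl gives a number 5 percentage points lower from compound 2 to compound 4 (within the scatter), so at this position, ortho to a methoxy group, hydrogen and methoxy cannot be told apart on this read-out. With the 4-methoxyphenyl group held constant, exchanging the oxime for the acetyl gives a number 3 percentage points lower from compound 1 to compound 4 (within the scatter), which shows that this change on the other aromatic ring also stays inside the usual spread. No measurement at hand speaks to the cause of either step.

Going by these compounds, it remains open whether a hydroxyl, a chlorine or an amine at the methoxy position would move the read-out beyond the scatter. The same question stands for a carboxylic acid in place of the acetyl and for a longer chain in place of the ethyl on the shared core.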